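This account rests on a few compounds, and the source may have more. Where it says the series, first, only, none or still open, it means among the compounds named here.

Working notes on the series. Two compounds carry measurements in a functional assay on HCT-116 cells (Homo sapiens) for cytotoxicity, read by sulforhodamine B assay, with a stated time of 24 h; on this read-out lower numbers stand for stronger inhibition and higher numbers for weaker inhibition. Among the measured compounds shown here, compound 1, `C/C=C(\C)C(=O)Nc1ccn([C@H]2CC[C@H](O[C@H]3O[C@H](C)[C@@H](N(C)C)[C@H](O)[C@H]3O)[C@@H](C)O2)c(=O)n1`, gives 6450 nM in this assay, the only numeric value in the set. Compound 2, `CC(C)=CCC(=O)Nc1ccn([C@H]2CC[C@H](O)[C@@H](C)O2)c(=O)n1`, returns only a limit in this assay, > 20000 nM, not a number. For the measured compounds named here, compound 2 therefore stands at the limit of > 20000 nM in this assay, at which 1 of the 2 values shown sits; how far past that limit it lies is not known, so no step from compound 1 to compound 2 can be sized, and the two values show only that compound 1 gives a number where compound 2 does not.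

Compound 3, `CCC(=O)Nc1ccn([C@H]2CC[C@H](O)[C@@H](C)O2)c(=O)n1`, is the next compound for this assay. It differs from compound 2 in one place: methyl in place of 2-methylprop-1-en-1-yl on a saturated chain carbon bound to a carbonyl carbon. The acyl chain is shortened and loses its unsaturation, with the rest of compound 2 unchanged.

With compound 2 already at a limit, the step from compound 2 to compound 3 is expected to be none beyond the scatter, a step that the limit leaves unreadable from compound 2 to compound 3, and a limit rather than a number is the likelier outcome. Compound 3 is accordingly estimated at 30000 nM in this assay, in the range 10000 nM to 100000 nM.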

Compound 3, half-maximal inhibitory concentration: > 20000 nM
Compound 3: only a limit was reported; the forecaster's own chance of this, stated with the estimate: 85%; the middle value does not contradict the limit.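

In this assay compound 3 returns > 20000 nM as a limit and not a number. Among the compounds shown here, compound 2 also gives only a limit, so no step from compound 2 to compound 3 can be read. Left open is how far past the limit each compound lies, and whether methyl in place of 2-methylprop-1-en-1-yl changes the read-out at all.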